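A few compounds are considered here, and "the series" means these few. Any claim that something is new, unique, unknown or untested is made for them only; others in the source may bear on it.

For the measured compounds named here, in a functional assay on HeLa cells (Homo sapiens) for inhibition, read by sulforhodamine B assay (on this read-out higher numbers stand for weaker inhibition and lower numbers for stronger inhibition), compound 2 `Cc1ccc(NC2=CC(=O)c3nc4n(c3C2=O)[C@H]2OC[C@@H](O)[C@H]2OC4)cc1` gives 3860 nM, the only exact number so far. Compound 1 `CCCN(CCC)C1=CC(=O)c2nc3n(c2C1=O)[C@H]1OC[C@@H](O)[C@H]1OC3` gives > 16000 nM, which is a limit of the assay. Compound 3 `O=C1C=C(N2CCCC2)C(=O)c2c1nc1n2[C@H]2OC[C@@H](O)[C@H]2OC1` has pyrrolidin-1-yl in place of (4-methylphenyl)amino on a double-bonded ring carbon. Going by the values given here, the one measured step bearing on this, an at least 4.1-fold lower number from compound 1 to compound 2 (0.61 log units; beyond the scatter), brought in that (4-methylphenyl)amino group in place of dipropylamino, so removing it is expected to undo part of that gain. The estimated move in this assay, towards weaker inhibition, is a 2.3-fold higher number from compound 2 to compound 3 (0.37 log units; beyond the scatter). For compound 3 the estimated value is 9000 nM, with an expected range of 3000 nM to 25000 nM.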

Compound 3, half-maximal inhibitory concentration: > 16000 nM
Compound 3: a limit, no number; the forecaster's own chance of this, stated with the estimate: 35%; at least 1.7-fold (0.24 log units) between middle value and limit.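

In this assay, placing pyrrolidin-1-yl on the double-bonded ring carbon gives an at least 4.1-fold higher number from compound 2 to compound 3 (0.61 log units; beyond the scatter), a step that rests on a limit for compound 3. So a ring amine, like the open-chain dipropylamino of compound 1, does not reach a measurable value here, while (4-methylphenyl)amino does. The step between compound 1 and compound 3 cannot be read, because both values are limits: the limit of > 16000 nM in this assay, at which 2 of the 3 values shown sit.

As far as these compounds go, compound 2 differs from compound 3 in both its aromatic ring and its hydrogen-bond donor, and which of these matters stays open. Cyclohexylamino, which keeps the donor without the aromatic ring, would help separate them.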